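This account rests on a few compounds, and the source may have more. Where it says the series, first, only, none or still open, it means among the compounds named here.

The measured compounds:
compound 1, `CCCC(=O)OCC1Oc2ccc([C@H]3Oc4cc(O)cc(O)c4C(=O)[C@@H]3O)cc2OC1c1ccc(O)c(OC)c1`, which in an ADME assay on MDCK cells (Canis lupus familiaris) for cytotoxicity, read by MTT assay, with a stated time of 2 h (on this read-out lower numbers stand for higher toxicity in this test and higher numbers for lower toxicity in this test), gives 300000 nM;
compound 2, `CCCCCCCCC(=O)OCC1Oc2ccc([C@H]3Oc4cc(O)cc(O)c4C(=O)[C@@H]3O)cc2OC1c1ccc(O)c(OC)c1`, which in this assay gives 30000 nM;
compound 3, `CCCCCCCCCCCC(=O)OCC1Oc2ccc([C@H]3Oc4cc(O)cc(O)c4C(=O)[C@@H]3O)cc2OC1c1ccc(O)c(OC)c1`, which in this assay gives 120000 nM.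

Compound 3 stands second highest of the three numbers; compound 1 lies nearest to it, and compound 2 lies furthest from it, on the lower side. The step of interest leads to compound 4, `CCCCCCCCCCCCCCCC(=O)OCC1Oc2ccc([C@H]3Oc4cc(O)cc(O)c4C(=O)[C@@H]3O)cc2OC1c1ccc(O)c(OC)c1`, and the structural change is butyl in place of hydrogen on a saturated chain carbon, ten or more bonds along the chain from a carbonyl carbon. Within the data shown here, three measured steps bear on it, each a growth of the same chain: a 10-fold lower number from compound 1 to compound 2 (1.00 log units; beyond the scatter), a 2.5-fold lower number from compound 1 to compound 3 (0.40 log units; beyond the scatter), and a 4.0-fold higher number from compound 2 to compound 3 (0.60 log units; beyond the scatter). These lengthening steps do not all point the same way: the first two lowered the number, the last raised it. Among the measured compounds shown here, because a 4.0-fold higher number from compound 2 to compound 3 (0.60 log units; beyond the scatter) raised the number as the chain grew, and is the step nearest in kind to the one now taken, a modest upward step is expected in this assay, though the opposing direction of the earlier steps keeps the range wide. Compound 4 is therefore expected to give about 200000 nM, with a range from 50000 nM to 600000 nM. This estimate means an expected step of a 1.7-fold higher number from compound 3 to compound 4 (0.22 log units; within the scatter).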

Compound 4, half-maximal cytotoxic concentration: > 480000 nM
Compound 4 was reported as a limit; the forecaster's own chance of this, stated with the estimate: 20%; middle value at least 2.4-fold (0.38 log units) from the limit.
By their numbers in this assay, from the lowest: compound 2; then compound 3; then compound 1. At a limit, above all of these: compound 4.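

The value of compound 4 in this assay is a limit, not a number: the limit of > 480000 nM in this assay, at which 1 of the 4 values shown sits.

Even so, the rise seen on the way to compound 3 does not reverse when butyl enters on a saturated chain carbon, with an at least 4.0-fold higher number from compound 3 to compound 4 (0.60 log units; beyond the scatter), and over the heptyl difference there is an at least 16-fold higher number from compound 2 to compound 4 (1.20 log units; beyond the scatter), a large step that extends the upward turn past compound 3. Against the shortest chain the picture is less firm, with an at least 1.6-fold higher number from compound 1 to compound 4 (0.20 log units; that floor lies within the scatter), so compound 4 cannot be placed clearly beyond compound 1, and the four compounds show a dip at compound 2 followed by a recovery rather than one steady trend, with compound 1 going against any rise with chain length.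

Going by these compounds, what the number would do with a chain longer than that of compound 4 stays open, including whether it goes on rising or levels off. Also open, on these data alone, is what a branched chain, or a chain ending in a carboxylic acid or an amine, would give at this position on the shared core.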